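Amino in place of hydrogen: compound 3 to compound 4

This account rests on a few compounds, and the source may have more. Where it says the series, first, only, none or still open, it means among the compounds named here.

Three compounds have been run in a functional assay on cells (Splenocyte, Mus musculus, strain BALB/c) for inhibition, read by scintillation counting and thymidine incorporation, with stated times of 48 h and 8 h; a higher number here means a weaker inhibitor, a lower number a stronger inhibitor. Compound 1 `CCc1ccc(-c2noc(Cc3c[nH]c4ccccc34)n2)cc1` gives 7500 nM in this assay. Compound 2 `Fc1ccccc1-c1nc(Cc2c[nH]c3ccccc23)no1` returns only a limit of the assay, > 50000 nM. Compound 3 `COc1cc(-c2noc(-c3ccccc3)n2)cc(OC)c1OC` likewise returns only a limit, > 50000 nM, so no number is known for it. Compound 3 thus stands at the limit of > 50000 nM in this assay, at which 2 of the 3 values shown sit, and compound 1 alone has a measured value. For the measured compounds named here, no two of the measured compounds differ in a single place, so no measured step exists to lean on.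

Compound 4 `COc1cc(-c2noc(-c3ccc(N)cc3)n2)cc(OC)c1OC` is the next compound, not yet measured in this assay. It differs from compound 3 by amino in place of hydrogen on an aromatic carbon. Going by the values given here, with compound 3 at a limit, the direction of any change cannot be read against a number, and no measured pair in the set shows what such a change does. The expectation is a modest gain at most, the estimated step being an at least 1.6-fold lower number from compound 3 to compound 4 (0.22 log units; that floor lies within the scatter). Compound 4 is therefore expected to give about 30000 nM, within 8000 nM to 100000 nM, with a fair chance that the assay again reports only a limit.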

Compound 4, half-maximal inhibitory concentration: 800 nM
For compound 4 the middle estimate is 38-fold (1.57 log units) above the measured one; the whole stated range lies above it.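

In this assay the change from phenyl to 4-aminophenyl gives the series its first step in one place, an at least 62-fold lower number from compound 3 to compound 4 (1.79 log units; beyond the scatter), which shows that this aromatic carbon, para to a large group, responds strongly to a single amino group. Compound 4 gives 800 nM, so the core of compound 3 now has a measured number. From the compounds shown here alone, the step remains a floor and its full size is unknown because compound 3 sits at a limit: the limit of > 50000 nM in this assay, at which 2 of the 4 values shown sit.

Going by these compounds, it remains open whether the gain belongs to the amino group alone or would also come with a hydroxyl, a dimethylamino or an acetamide on the same carbon. On these data alone, it is equally open whether an amino group would have a comparable effect on the aromatic rings of compound 1 and compound 2, whose cores differ from that of compound 4 in more than one place.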